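This account rests on a few compounds, and the source may have more. Where it says the series, first, only, none or still open, it means among the compounds named here.

In a functional assay on RAW264.7 cells (Mus musculus), read by Griess assay, with a stated time of 15 min (on this read-out higher numbers stand for weaker inhibition and lower numbers for stronger inhibition), compound 1 (`C/C=C(\C)C(=O)O[C@H]1C[C@@H](C)[C@]2(O)CC[C@](C)(/C=C3/OC(=O)C(CO)=C31)O2`) gives 5700 nM and compound 2 (`CO[C@]12CC[C@](C)(/C=C3/OC(=O)C(CO)=C3[C@@H](O)C[C@H]1C)O2`) gives 28100 nM while compound 3 (`C/C=C(\C)C(=O)O[C@H]1C[C@@H](C)[C@]2(OC)CC[C@](C)(/C=C3/OC(=O)C(COC(C)=O)=C31)O2`) gives 1200 nM as the lowest of the three numbers, with both gaps beyond the scatter. Compound 4 (`C/C=C(\C)C(=O)O[C@H]1C[C@@H](C)[C@]2(OC)CC[C@](C)(/C=C3/OC(=O)C(CO)=C31)O2`) has not yet been measured. The change from compound 3 to compound 4 is acetoxymethyl to hydroxymethyl (hydrogen in place of acetyl on an oxygen on a saturated carbon), that is, hydrogen in place of acetyl on an oxygen on a saturated carbon. For the measured compounds named here, no two measured compounds differ in one place only, so this assay offers no direct precedent for this step. Compound 1 also carries hydroxymethyl and stands at 5700 nM with another difference from compound 3 elsewhere on the shared core, which makes it an indirect guide only. A moderate move to a higher number, meaning weaker inhibition and lying beyond the scatter, is expected (a 2.9-fold higher number from compound 3 to compound 4 (0.46 log units; beyond the scatter)). The estimated value for compound 4 is 3500 nM (expected range 1300 nM to 9000 nM).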

Compound 4, half-maximal inhibitory concentration: 2400 nM
Compound 4: the middle estimate sits 1.5-fold (0.16 log units) above what was measured; low and high end bracket the measured number.
By their numbers in this assay, from the lowest: compounds 3 and 4 (each within the scatter of the next); then compound 1; then compound 2.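

In this assay, the acetoxymethyl and hydroxymethyl groups cannot be told apart at this position (a 2.0-fold higher number from compound 3 to compound 4 (0.30 log units; within the scatter)), so in this pair the acetyl on the oxygen on a saturated carbon is not needed for the inhibition read. Compound 4 also links two other single changes on the shared core: methyl in place of hydrogen on an oxygen on a saturated carbon gives a modest step (a 2.4-fold lower number from compound 1 to compound 4 (0.38 log units; beyond the scatter)), and (1-methylprop-1-en-1-yl)carbonyl in place of hydrogen on an oxygen on a saturated carbon gives a large one (a 12-fold lower number from compound 2 to compound 4 (1.07 log units; beyond the scatter)). No data here explain any of these steps.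

Open at this position is whether an amine, a carboxylic acid or a longer acyl chain would read like hydroxymethyl and acetoxymethyl. Also open, going by these compounds, is whether the three steps would hold on other substituted versions of the core.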